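From a Heptyl Chain to Trifluoromethyl on a Shared Core

The source may report more compounds than this note shows. Statements on the series, on what has been measured and on what is new or still open speak of the compounds shown alone.

Three compounds share one core: compound 1 `Cc1ccc(NC(=O)N[C@H](C)c2ccccc2)cc1`, compound 2 `CCCCCCc1ccc(NC(=O)N[C@H](C)c2ccccc2)cc1` and compound 3 `CCCCCCCc1ccc(NC(=O)N[C@H](C)c2ccccc2)cc1`. In an ADME assay on the whole organism with Oryza sativa as the target, tested at 1 uM (a higher number here means a weaker effect of the compound at the concentration tested, a lower number a stronger effect), compound 1 gives 98%, compound 2 gives 101% and compound 3 gives 100%. Compound 3 stands second highest of the three, with both neighbouring steps inside the scatter: a number 2 percentage points higher from compound 1 to compound 3 (within the scatter) and a number 1 percentage points lower from compound 2 to compound 3 (within the scatter). The unmeasured compound 4 `C[C@@H](NC(=O)Nc1ccc(C(F)(F)F)cc1)c1ccccc1` differs from compound 3 by trifluoromethyl in place of heptyl on an aromatic carbon. For the measured compounds named here, the steps measured so far, a number 3 percentage points higher from compound 1 to compound 2 (within the scatter) and a number 2 percentage points higher from compound 1 to compound 3 (within the scatter), only lengthened a chain at this place; no measured compound carries a trifluoromethyl there, so they bear on the change only loosely and point to no step beyond the scatter. Compound 4 is therefore expected to give about 100% in this assay, between 90% and 110%, an expected step of no change at the digits printed from compound 3 to compound 4 (within the scatter).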

Compound 4, a percentage reported as activity, at one concentration (the size of the read-out at that concentration, not a potency): 89%
Estimate against measurement, compound 4: 11 percentage points above; the whole stated range lies above it.
By their numbers in this assay, from the lowest: compounds 4, 1, 3 and 2 (each within the scatter of the next, the first and the last beyond it).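

Lengthening the chain at this place moved nothing beyond the scatter in this assay, whereas trifluoromethyl gives the first steps that pass it, both modest (a number 11 percentage points lower from compound 3 to compound 4 (beyond the scatter); a number 12 percentage points lower from compound 2 to compound 4 (beyond the scatter)). Against the methyl of compound 1 the same group does not separate (a number 9 percentage points lower from compound 1 to compound 4 (within the scatter)), so the change shows only against the two longer chains. Nothing available explains this difference.

As far as these compounds go, it remains open whether the step belongs to trifluoromethyl itself or to the loss of a long chain. A chlorine, a nitrile or an ethyl group at this place could help to tell the two apart.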